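The source may report more compounds than this note shows. Statements on the series, on what has been measured and on what is new or still open speak of the compounds shown alone.

In an ADME assay on microsomes from liver (Homo sapiens) for metabolic stability, with a stated time of 10 min (a lower number here means that less of the compound is left, a higher number that more of the compound is left), compound 1 `COC1(c2nnc3c(Oc4cccc(Cl)c4C)cccn23)CCCCCC1` gives < 1% as a limit of the assay, not a number. Compound 2 `Cc1c(Cl)cccc1Oc1cccn2c(C3CCC(C)(O)CC3)nnc12` gives 99% and compound 3 `Cc1c(Cl)cccc1Oc1cccn2c(C3CCOCC3)nnc12` gives 100% on the same read-out. The gap between these two is a number 1 percentage points higher from compound 2 to compound 3 (within the scatter) and so compound 3 shares the high end of the numbers with compound 2.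

Compound 4 `CC(=O)N1CCC(c2nnc3c(Oc4cccc(Cl)c4C)cccn23)CC1` has 1-acetylpiperidin-4-yl in place of oxan-4-yl on an aromatic carbon and is otherwise unchanged. Two large steps touch this same place: a number at least 98 percentage points higher from compound 1 to compound 2 (beyond the scatter) and a number at least 99 percentage points higher from compound 1 to compound 3 (beyond the scatter) both start from compound 1, whose 1-methoxycycloheptyl goes against the high values of the other two. Compound 4 keeps a six-membered non-aromatic ring with 1 hetero atom, as compound 3 does, so it is expected to stay near compound 3 in this assay with at most a small fall. The expected step is a number 8 percentage points lower from compound 3 to compound 4 (within the scatter) and three compounds cannot rule out a larger one. Compound 4 is estimated at 92% with a range from 70% to 100% on this read-out.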

Compound 4, percent of the compound remaining: 87%
Beside the measured number, compound 4's estimate is 5 percentage points above it; the measured number falls inside the stated range.
By their numbers in this assay, from the lowest: compound 4; then compounds 2 and 3 (each within the scatter of the next). At a limit, below all of these: compound 1.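

In this assay, among the compounds shown here, the oxan-4-yl and 4-hydroxy-4-methylcyclohexyl groups could not be told apart, but this change gives the first step beyond the scatter among groups that hold the number high, with a number 13 percentage points lower from compound 3 to compound 4 (beyond the scatter) and a number 12 percentage points lower from compound 2 to compound 4 (beyond the scatter). Keeping a six-membered non-aromatic ring with 1 hetero atom therefore does not by itself hold the number at the top, although the step up from the low end remains large, with a number at least 86 percentage points higher from compound 1 to compound 4 (beyond the scatter). Compound 1 stands at a limit, not a number: the limit of < 1% in this assay, at which 1 of the 4 values shown sits.

The compounds shown do not separate the effect of the acetyl group from that of the ring nitrogen carrying it. A piperidine with a free amine, or with a longer acyl chain on that nitrogen, would help to tell these two apart.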